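The source may report more compounds than this note shows. Statements on the series, on what has been measured and on what is new or still open speak of the compounds shown alone.

Measured compounds:
compound 1, `O=Cc1cccc(OCc2cn(Cc3ccccc3)nn2)c1` — > 50000 nM
compound 2, `O=C1Nc2ccc(F)cc2/C1=C\c1cccc(OCc2cn(Cc3ccccc3)nn2)c1` — "not determined" (no result reported)

In a functional assay on DU-145 cells (Homo sapiens) for inhibition, read by MTT assay, with a stated time of 48 h (a lower number here means a stronger inhibitor, a higher number a weaker inhibitor), compound 1 gives > 50000 nM, which is a limit of the assay and not a number. Compound 2 carries no result in this assay, so it stands nowhere on the numbers shown; among the two values given, one sits at the limit of > 50000 nM in this assay, at which 1 of the 2 values shown sits, and the other is empty. The account therefore has nothing to anchor the step on the side of compound 2.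

Compound 3, `O=C1Nc2ccc(C(=O)c3ccccc3)cc2/C1=C\c1cccc(OCc2cn(Cc3ccccc3)nn2)c1`, differs from compound 2 by benzoyl in place of fluoro on an aromatic carbon. Going by the values given here, with no measured step between any two compounds of this set, no size of change in this assay can be read off; the only number, the limit for compound 1, belongs to a smaller structure that both compound 2 and compound 3 contain. The estimate for compound 3 in this assay is 5000 nM, expected to fall between 800 nM and 30000 nM.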

Compound 3, half-maximal inhibitory concentration: > 50000 nM
Compound 3: no number, only a limit; the forecaster's own chance of this, stated with the estimate: 30%; at least 10-fold (1.00 log units) between middle value and limit.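

In this assay compound 3 gives > 50000 nM, which is a limit of the assay and not a number, so no step can be read between compound 2 and compound 3. The compounds shown leave open whether benzoyl or fluoro on the shared core changes inhibition at all.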